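This account rests on a few compounds, and the source may have more. Where it says the series, first, only, none or still open, it means among the compounds named here.

Of the compounds shown here, two have been tested in a functional assay on HepG2 cells (Homo sapiens) for cytotoxicity, read by MTT assay, with a stated time of 48 h; a higher number here means a weaker inhibitor, a lower number a stronger inhibitor. Compound 1 `CC1=NN(S(=O)(=O)c2ccc(C)cc2)C(c2cc(Br)cc(Br)c2O)C1` was reported in this assay as "not active" (no number reported), with no number attached. Within the data shown here, compound 2 `CCC(=O)N1N=C(c2cc3ccccc3oc2=O)CC1c1ccccc1` gives 9610 nM in this assay, the only value on a numerical scale here, so it stands alone with nothing to rank it against. Compound 3 `O=C(CN1CCCC1)N1N=C(c2cc3ccccc3oc2=O)CC1c1ccccc1` is the next to be measured; it differs from compound 2 by pyrrolidin-1-yl in place of methyl on a saturated chain carbon bound to a carbonyl carbon. Among the measured compounds shown here, no pair of measured compounds shows what this kind of change does, so no step beyond the usual scatter is expected in either direction. The estimated step is a 1.1-fold lower number from compound 2 to compound 3 (0.03 log units; within the scatter). Compound 3 is therefore expected to give about 9000 nM, within a range from 3000 nM to 30000 nM.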

Compound 3, half-maximal inhibitory concentration: 44300 nM
Compound 3: the middle estimate sits 4.9-fold (0.69 log units) below what was measured; the whole stated range lies below it.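

In this assay pyrrolidin-1-yl in place of methyl on a saturated chain carbon bound to a carbonyl carbon brings a 4.6-fold higher number from compound 2 to compound 3 (0.66 log units; beyond the scatter) and so shows that this place is sensitive to what it carries. Here the larger, nitrogen-bearing group goes with the weaker result. No measurement given here explains this step. Still open, going by these compounds, is whether the ring or its nitrogen matters more: a cyclopentyl group would keep a ring without that nitrogen, and a dimethylamino group would keep an amine without the ring.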